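Two Aryl Swaps on a Sulfonamide-Amide Scaffold

The source may hold more compounds than are shown below. What is called first, only, known or untested is meant among the compounds shown, and "the series" means these compounds.

compound 1 `Cc1cccc(S(=O)(=O)NCc2ccc(CNC(=O)c3cccnc3)cc2)c1`: 10 nM
compound 2 `COc1ccccc1C(=O)NCc1ccc(CNS(=O)(=O)c2cccc(C)c2)cc1`: 1000 nM
compound 3 `O=C(NCc1ccc(CNS(=O)(=O)c2ccc(Cl)cc2)cc1)c1cccnc1`: 1000 nM

In an assay on MDA-MB-231 cells for displacement of a labelled ligand from C-X-C chemokine receptor type 4 (Homo sapiens), read by fluorescence and microscopy, with stated times of 10 min and 30 min (a lower number here means that less compound is needed, a higher number that more compound is needed for the effect), compound 1 gives 10 nM. Compound 2 differs from it by 2-methoxyphenyl in place of pyridin-3-yl on a carbonyl carbon, a change that made a 100-fold higher number from compound 1 to compound 2 (2.00 log units; beyond the scatter). Compound 3 differs from compound 1 in the other ring, (4-chlorophenyl in place of 3-methylphenyl on a sulfonyl sulfur), and shows a 100-fold higher number from compound 1 to compound 3 (2.00 log units; beyond the scatter), so that compound 3 in this assay gives 1000 nM, level with compound 2. Compound 4 `COc1ccccc1C(=O)NCc1ccc(CNS(=O)(=O)c2ccc(Cl)cc2)cc1` arises from compound 3 by the same change as before, (2-methoxyphenyl in place of pyridin-3-yl on a carbonyl carbon), on a core that carries the 4-chlorophenyl instead of the 3-methylphenyl. A smaller step than the earlier one is expected, a 3.0-fold higher number from compound 3 to compound 4 (0.48 log units; beyond the scatter), because compound 3 already gives 1000 nM and the two changes may not add in full. Compound 4 is estimated at 3000 nM, with a range from 1000 nM to 30000 nM.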

Compound 4, effective concentration (reported as EC, without a stated level of effect): 1000 nM
The estimate for compound 4 lay 3.0-fold (0.48 log units) above the measured number; measured number inside the range.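

In this assay, 2-methoxyphenyl in place of pyridin-3-yl brings no change at the digits printed from compound 3 to compound 4 (within the scatter), and 4-chlorophenyl in place of 3-methylphenyl brings no change at the digits printed from compound 2 to compound 4 (within the scatter). The first change therefore does not carry over from one core to the other at a fixed size: the same change on two cores in this assay, a 100-fold higher number (2.00 log units; beyond the scatter) from compound 1 to compound 2 and no change at the digits printed (within the scatter) from compound 3 to compound 4, 100-fold (2.00 log units) apart, beyond the scatter of two such steps. The second change does not carry over either, although these four compounds do not show why the size of a step depends on the core, or how either change would behave on any further core: the same change on two cores in this assay, a 100-fold higher number (2.00 log units; beyond the scatter) from compound 1 to compound 3 and no change at the digits printed (within the scatter) from compound 2 to compound 4, 100-fold (2.00 log units) apart, beyond the scatter of two such steps.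

The compounds shown leave open whether the low number of compound 1 needs pyridin-3-yl and 3-methylphenyl together. They also leave open what a pyridin-4-yl on the carbonyl carbon or a piperidine on the sulfonyl sulfur would give.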